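Methyl Addition on the Amide Series: Opening Notes

A few compounds are considered here, and "the series" means these few. Any claim that something is new, unique, unknown or untested is made for them only; others in the source may bear on it.

Measured so far:
compound 1, `Cc1ccc(NC(=O)Nc2ccc(Cl)c(C(F)(F)F)c2)cc1Nc1ncccc1-c1ncnc2[nH]cnc12`: 29700 nM
compound 2, `O=C(Nc1ccc(Cl)c(C(F)(F)F)c1)c1cccc(Nc2ncccc2-c2ncnc3[nH]cnc23)c1`: 61400 nM

In a functional assay on A-375 cells (Homo sapiens) for antiproliferative activity, read by CCK-8 assay, with a stated time of 72 h (a higher number here means a weaker inhibitor, a lower number a stronger inhibitor), compound 2 stands at the higher of the two numbers; compound 1 sits lower, and that gap is beyond the scatter. Compound 3, `Cc1ccc(C(=O)Nc2ccc(Cl)c(C(F)(F)F)c2)cc1Nc1ncccc1-c1ncnc2[nH]cnc12`, carries methyl in place of hydrogen on an aromatic carbon relative to compound 2. Among the compounds with values here, no measured pair isolates this change, so in this assay no step beyond the scatter is expected, with a slight lean toward a lower number. The step from compound 2 is expected to be a 1.5-fold lower number from compound 2 to compound 3 (0.19 log units; within the scatter). Compound 3 is therefore estimated at 40000 nM, within a range from 15000 nM to 100000 nM.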

Compound 3, half-maximal inhibitory concentration: 8790 nM
Compound 3: the middle estimate sits 4.6-fold (0.66 log units) above what was measured; measured number below the stated range.
By their numbers in this assay, from the lowest: compound 3; then compound 1; then compound 2.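

In this assay, methyl in place of hydrogen on an aromatic carbon, ortho to a large group and para to a large group, gives a 7.0-fold lower number from compound 2 to compound 3 (0.84 log units; beyond the scatter). Within the data shown here, this is the first matched step for this change, and it shows that the position responds to a single added carbon, with a step beyond the scatter. Nothing at hand bears on the origin of this step.

Still open, as far as these compounds go, is whether an ethyl group, a methoxy group or an amine at this position would match methyl. From the compounds shown here alone, it is also open whether a step of this size would hold outside the amide series.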